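The compounds below may be only part of what the source reports. "The series", "measured", "known", "first", "only" and "open" are said of these compounds alone.

Measured compounds:
Compound 1 `CC(C)(C)Nc1nc(N)c(C(=O)N=C(N)N)nc1Cl` gives 48% in an assay for inhibition of acid-sensing ion channel 3 (Homo sapiens), read by patch clamp, tested at 20 uM; on this read-out higher numbers stand for more inhibition at the one concentration tested (going by the name of the read-out) and lower numbers for less inhibition.
Compound 2 `NC(N)=NC(=O)c1nc(Cl)c(NC2CCCCC2)nc1N` gives 92% in this assay.
Compound 3 `NC(N)=NC(=O)c1nc(Cl)c(Nc2ccccn2)nc1N` gives 25% in this assay.

Compound 3 stands lowest of the three: a number 23 percentage points lower from compound 1 to compound 3 (beyond the scatter), and a number 67 percentage points lower from compound 2 to compound 3 (beyond the scatter). Both steps lead from a saturated group on the ring nitrogen to the pyridin-2-yl group and both go down, though the pair of saturated groups also differ among themselves, since a number 44 percentage points higher from compound 1 to compound 2 (beyond the scatter).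

Compound 4 `NC(N)=NC(=O)c1nc(Cl)c(Oc2ccccc2)nc1N` has not been measured. It differs from compound 3 in one place: phenoxy in place of (pyridin-2-yl)amino on an aromatic carbon. Among the compounds with values here, no measured step changes the linking atom itself; the three steps only exchange the group carried on the nitrogen. Within the data shown here, the only guidance is that the one aromatic group seen so far, in compound 3, sits at the bottom of the series, and compound 4 keeps an aromatic ring at that position. Compound 4 is therefore expected to stay in the lower part of the range, with a step estimated at a number 10 percentage points higher from compound 3 to compound 4 (within the scatter). The value estimated for compound 4 in this assay is 35%, likely between 10% and 65%.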

Compound 4, a percentage reported as inhibition, at one concentration (the size of the read-out at that concentration, not a potency): 90%
Beside the measured number, compound 4's estimate is 55 percentage points below it, outside the stated range (above it).
By their numbers in this assay, from the lowest: compound 3; then compound 1; then compounds 4 and 2 (each within the scatter of the next).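

In this assay an aromatic ring at this position does not by itself go with a low number: phenoxy in place of (pyridin-2-yl)amino gives a number 65 percentage points higher from compound 3 to compound 4 (beyond the scatter) and phenoxy in place of (tert-butyl)amino gives a number 42 percentage points higher from compound 1 to compound 4 (beyond the scatter). Phenoxy in place of cyclohexylamino gives a number 2 percentage points lower from compound 2 to compound 4 (within the scatter) and so leaves a group with an aromatic ring and a group with a saturated ring level here. Nothing available explains the rise seen with phenoxy.

On these data alone, the change from compound 3 to compound 4 swaps both the linking atom and the ring nitrogen, so which of the two matters stays open. A phenylamino group, with a nitrogen link and a carbon-only ring, or a pyridin-2-yloxy group, with an oxygen link and the ring nitrogen kept, would separate them.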